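The source may report more compounds than this note shows. Statements on the series, on what has been measured and on what is new or still open speak of the compounds shown alone.

Measured compounds in a toxicity assay on HepG2 2.2.15 cells (Homo sapiens) for cytotoxicity, read by CCK-8 assay, with a stated time of 8 days; a higher number here means that more compound is tolerated, a lower number that less compound is tolerated:

Compound 1 `CC(C)Cc1nn(-c2nccs2)cc1C(=O)NCc1ccc(F)cc1F` gives 83600 nM in this assay.
Compound 2 `CCOC(=O)c1cn(-c2nccs2)nc1CC(C)C` gives > 100000 nM in this assay, which is a limit of the assay and not a number.
Compound 3 `COc1ccc(CNC(=O)c2cn(-c3nccs3)nc2CC(C)C)cc1` gives > 100000 nM in this assay, again a limit of the assay and not a number.

Compound 3 therefore stands at the upper limit of this assay, where two of the three values sit (the limit of > 100000 nM in this assay, at which 2 of the 3 values shown sit); only compound 1 has a number below it.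

Compound 4 `CC(C)Cc1nn(-c2nccs2)cc1C(=O)NCc1ccc(C(F)(F)F)cc1` is the next step. Its change against compound 3 is trifluoromethyl in place of methoxy on an aromatic carbon.

Among the measured compounds shown here, one measured step bears on this position, the exchange of the substituted phenyl on the benzylic carbon: an at least 1.1-fold higher number from compound 1 to compound 3 (0.07 log units; that floor lies within the scatter). That step reaches the limit, and its floor lies within the scatter, so the shown data give no direction for a substituent change on this ring. Since both groups in the step sit on an aromatic carbon of the same ring, a change within the scatter is expected for compound 4, in either direction or none.

Compound 4 is estimated at 90000 nM in this assay, between 40000 nM and 200000 nM. The expected step is an at least 1.1-fold lower number from compound 3 to compound 4 (0.04 log units; that floor lies within the scatter), and a limit reading is likely.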

Compound 4, half-maximal cytotoxic concentration: > 100000 nM
Compound 4: no number, only a limit; the forecaster's own chance of this, stated with the estimate: 50%; at least 1.1-fold (0.04 log units) between middle value and limit.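

In this assay compound 4 gives > 100000 nM, a limit of the assay and not a number. Compound 3 also stands at a limit, so the step between compound 3 and compound 4 cannot be read. The compounds shown leave open whether trifluoromethyl and methoxy differ at all in this assay.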